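A few compounds are considered here, and "the series" means these few. Any claim that something is new, unique, unknown or untested is made for them only; others in the source may bear on it.

Compound 1 `COc1ccc(Cn2cc(CSC(=S)N3CCN(C(=O)OCc4ccccc4)CC3)nn2)cc1` gives 23800 nM in a functional assay on MGC-803 cells (Homo sapiens) for inhibition, read by MTT assay, with a stated time of 72 h; a higher number here means a weaker inhibitor, a lower number a stronger inhibitor.
Compound 2 `S=C(SCc1cn(Cc2ccccc2Cl)nn1)N1CCNCC1` gives 45200 nM in this assay.
Compound 3 `Cc1cc(=O)oc2cc(OCCn3cc(CSC(=S)N4CCN(C(=O)OC(C)(C)C)CC4)nn3)ccc12` gives 76900 nM in this assay.

Among these three numbers compound 3 carries the highest one. Compound 2 lies closest to it, and that gap is within the usual scatter of repeated measurements, so no order between compound 2 and compound 3 can be read from the values. Compound 1 lies furthest from compound 3, and that gap is beyond the scatter, so of the two it is compound 1 that gives the lower number.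

Compound 4 `CC(C)(C)OC(=O)N1CCN(C(=S)SCc2cn(CCOc3ccc4ccc(=O)oc4c3)nn2)CC1` differs from compound 3 in one place: hydrogen in place of methyl on an aromatic carbon. For the measured compounds named here, no pair of measured compounds differs in this way alone, so no measured step guides the expectation. For compound 4, the expected step of a 1.1-fold lower number from compound 3 to compound 4 (0.04 log units; within the scatter) is set within the scatter, with no direction claimed. Compound 4 is therefore expected to give about 70000 nM in this assay, with a range from 30000 nM to 160000 nM.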

Compound 4, half-maximal inhibitory concentration: 67100 nM
Compound 4: middle estimate off by 1.0-fold (0.02 log units), on the high side; the range from low to high includes it.
By their numbers in this assay, from the lowest: compounds 1, 2, 4 and 3 (each within the scatter of the next, the first and the last beyond it).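

For the compounds shown here, the exchange of methyl for hydrogen gives the first step between measured compounds that differ in one place: on an aromatic carbon of the six-membered aromatic ring with 1 oxygen, opposite the ring oxygen, the step in this assay is a 1.1-fold lower number from compound 3 to compound 4 (0.06 log units; within the scatter). At this position, then, the methyl group can be replaced by hydrogen with no difference that can be read from these two values. Nothing measured here offers an explanation for this result.

The compounds shown leave open whether a methoxy group, an amine, a carboxylic acid or a longer chain such as ethyl on this carbon would give a number that differs beyond the scatter. They also leave open whether the same exchange gives a similar step on a compound with another group at the far end of the molecule, such as a benzyl carbamate.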